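Pyridazin-3-yl in place of pyrazin-2-yl: working notes

This account rests on a few compounds, and the source may have more. Where it says the series, first, only, none or still open, it means among the compounds named here.

Compound 1 `CNC(=O)c1nnc(NC(=O)C2CC2)cc1Nc1cccc(-c2cnccn2)c1OC` gives 1%
Compound 2 `CNC(=O)c1nnc(NC(=O)C2CC2)cc1Nc1cccc(-c2ccncn2)c1OC` gives 3%

Among the measured compounds shown here, in an ADME assay on microsomes from liver (Rattus norvegicus) for metabolic stability, with a stated time of 10 min (a higher number here means that more of the compound is left, a lower number that less of the compound is left), compound 1 stands within the scatter of compound 2, the only other measured number. Compound 3 `CNC(=O)c1nnc(NC(=O)C2CC2)cc1Nc1cccc(-c2cccnn2)c1OC` carries one change from compound 1: pyridazin-3-yl in place of pyrazin-2-yl on an aromatic carbon with pyridazin-3-yl in place of pyrazin-2-yl on an aromatic carbon. For the measured compounds named here, the one measured step bearing on this is a number 2 percentage points higher from compound 1 to compound 2 (within the scatter) with pyrimidin-4-yl in place of pyrazin-2-yl on an aromatic carbon. A single step is thin support, yet no change beyond the scatter is expected in this assay here. The expected step is a number 3 percentage points higher from compound 1 to compound 3 (within the scatter) by this estimate. For compound 3 the estimate is 4% with an expected range of 1% to 12% for the measurement.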

Compound 3, percent of the compound remaining: 8%
Compound 3: middle estimate off by 4 percentage points, on the low side, within the range that was stated.
By their numbers in this assay, from the lowest: compounds 1, 2 and 3 (each within the scatter of the next).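

In this assay, pyridazin-3-yl on the aromatic carbon ortho to a methoxy group gives a number 7 percentage points higher from compound 1 to compound 3 (within the scatter) and a number 5 percentage points higher from compound 2 to compound 3 (within the scatter). Across pyrazin-2-yl, pyrimidin-4-yl and pyridazin-3-yl, moving the ring nitrogens at this position has thus produced no step beyond the scatter. No measurement at hand accounts for these numbers. Still open, going by these compounds, is whether an amine or a carboxylic acid in place of the ring at this position would shift the percentage remaining beyond the scatter.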